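The source may report more compounds than this note shows. Statements on the series, on what has been measured and on what is new or still open speak of the compounds shown alone.

Measured so far:
compound 1 `C=CCN(C)C(=O)c1ccc(C(CC)(CC)c2ccc(OCC(=O)C(C)(C)C)c(C)c2)n1CC` — 21600 nM
compound 2 `CCN(CC)CCNC(=O)c1ccc(C(CC)(CC)c2ccc(OCC(O)C(C)(C)C)c(C)c2)n1CC` — 110 nM

In an assay on HL-60 cells for agonist activity at vitamin D3 receptor (Homo sapiens), read by microscopy, with a stated time of 96 h (on this read-out higher numbers stand for an effect only at larger amounts of compound and lower numbers for an effect already at smaller amounts), compound 2 gives 110 nM, the lowest of the two numbers seen here, while compound 1 gives 21600 nM, a gap that lies well beyond the usual scatter. Compound 1 and compound 2 differ in more than one place, so no single change can be read from that gap.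

Compound 3 `CCn1c(C(=O)N(C)c2ccccc2)ccc1C(CC)(CC)c1ccc(OCC(O)C(C)(C)C)c(C)c1` is not yet measured. It differs from compound 2 in one place: methyl(phenyl)amino in place of (2-(diethylamino)ethyl)amino on a carbonyl carbon. The hydrogen-bond donor and the acceptor of the leaving group are gone; an aromatic ring comes in.

Among the compounds with values here, there is no measured pair that isolates this exact change. The one tertiary amide in this set, compound 1, sits at the weak end, so for compound 3 a step toward a larger number is expected. The expected step is estimated as a 14-fold higher number from compound 2 to compound 3 (1.13 log units; beyond the scatter), with considerable uncertainty. The expected value for compound 3 in this assay is 1500 nM, somewhere between 200 nM and 12000 nM.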

Compound 3, half-maximal effective concentration: 6400 nM
The estimate for compound 3 lay 4.3-fold (0.63 log units) below the measured number; the measured number falls inside the stated range.
By their numbers in this assay, from the lowest: compound 2; then compound 3; then compound 1.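

In this assay, within the data shown here, putting methyl(phenyl)amino in place of (2-(diethylamino)ethyl)amino on the carbonyl carbon gives a 58-fold higher number from compound 2 to compound 3 (1.76 log units; beyond the scatter) and is the first single change here that can be read. The number at this position therefore depends strongly on the group attached, even though both groups have 8 heavy atoms. No measurement here explains the step. 

The change removes the hydrogen-bond donor and acceptor of the leaving group and the chain that carries diethylamino, and it brings in an aromatic ring, so these contributions remain tangled together. Phenylamino, which keeps the ring and restores the amide hydrogen, and methyl(2-(diethylamino)ethyl)amino, which keeps the chain and lacks that hydrogen, would help separate them.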